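This account rests on a few compounds, and the source may have more. Where it says the series, first, only, none or still open, it means among the compounds named here.

Measured so far in an assay for inhibition of HSP60/HSP10 (Homo sapiens), with a stated time of 60 min; a higher number here means a weaker inhibitor, a lower number a stronger inhibitor:
compound 1 `O=C(Nc1ccc(Sc2nc3ccccc3s2)c(Cl)c1)c1cccc(Br)c1O` gives 6900 nM.
Compound 2 `COc1c(Br)cc(Br)cc1C(=O)Nc1ccc(Sc2nc3ccccc3s2)c(Cl)c1` gives > 100000 nM, a limit of this assay rather than a number.
Compound 3 `O=C(Nc1ccc(Sc2nc3ccccc3s2)c(Cl)c1)c1cccc(Br)c1` gives > 100000 nM, likewise a limit.

Within the data shown here, compound 1 thus holds the only number in the set; the two other values sit at the limit of > 100000 nM in this assay, at which 2 of the 3 values shown sit. Both measured steps change the ring on the carbonyl carbon: an at least 14-fold higher number from compound 1 to compound 2 (1.16 log units; beyond the scatter), and an at least 14-fold higher number from compound 1 to compound 3 (1.16 log units; beyond the scatter).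

Compound 4 `O=C(Nc1ccc(Sc2nc3ccccc3s2)cc1)c1cccc(Br)c1O` differs from compound 1 by hydrogen in place of chloro on an aromatic carbon. Among the measured compounds shown here, no measured step touches this position, so none of the steps above bears on it directly, and no step beyond the scatter is expected: a 1.2-fold higher number from compound 1 to compound 4 (0.06 log units; within the scatter). For compound 4 the expected value in this assay is 8000 nM, in the range 3000 nM to 25000 nM.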

Compound 4, half-maximal inhibitory concentration: 26000 nM
Compound 4: middle estimate off by 3.3-fold (0.51 log units), on the low side; the whole stated range lies below it.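

In this assay, the step of a 3.8-fold higher number from compound 1 to compound 4 (0.58 log units; beyond the scatter) shows that the chloro position of the core is not silent: hydrogen in place of chloro weakens the inhibitor beyond the scatter. The change is modest next to the steps on the ring on the carbonyl carbon, and compound 4 still gives a readable number. Nothing shown accounts for the size of this step.

From the compounds shown here alone, it remains open whether fluoro, methyl or an amine at this place would match chloro. Going by these compounds, whether removing chloro costs the same without the hydroxy also remains open.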